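Replacing naphthalen-1-yl with 3,4,5-trimethoxyphenyl on compound 2

A few compounds are considered here, and "the series" means these few. Any claim that something is new, unique, unknown or untested is made for them only; others in the source may bear on it.

Compound 2 (`COc1cc(/C=C/C(=O)/C=C/c2cccc3ccccc23)ccc1OCc1cn(CCCCOc2cc(=O)oc3ccccc23)nn1`) gives 56% in a functional assay on HCT-116 cells (Homo sapiens) for inhibition, read by sulforhodamine B assay, with a stated time of 48 h, tested at 50 uM (a higher number here means more inhibition of growth at the concentration tested, a lower number less inhibition of growth), and stands level, within the scatter, with compound 3 (`COc1cccc(/C=C/C(=O)/C=C/c2ccc(OCc3cn(CCCOc4cc(=O)oc5ccccc45)nn3)c(OC)c2)c1`) at 55% as its nearest neighbour. Compound 1 (`COc1cc(/C=C/C(=O)/C=C/c2cccc3ccccc23)ccc1OCc1cn(CCCCCOc2cc(=O)oc3ccccc23)nn1`) gives 42% and lies beyond the scatter under compound 2.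

Compound 4 (`COc1cc(/C=C/C(=O)/C=C/c2cc(OC)c(OC)c(OC)c2)ccc1OCc1cn(CCCCOc2cc(=O)oc3ccccc23)nn1`) departs from compound 2 by one exchange (3,4,5-trimethoxyphenyl in place of naphthalen-1-yl on a double-bonded chain carbon bound to a double-bonded chain carbon), 3,4,5-trimethoxyphenyl in place of naphthalen-1-yl on a double-bonded chain carbon bound to a double-bonded chain carbon. Going by the values given here, no measured pair shows this exchange, so the step in this assay rests on expectation alone: none beyond the scatter, in either direction. The expected step (a number 2 percentage points lower from compound 2 to compound 4 (within the scatter)) stays within the scatter. For compound 4 the estimated value is 54% with a range (39% to 69%).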

Compound 4, percent growth inhibition at one concentration: 63%
Compound 4: the middle estimate sits 9 percentage points below what was measured, within the range that was stated.
By their numbers in this assay, from the lowest: compound 1; then compounds 3, 2 and 4 (each within the scatter of the next).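

The exchange to 3,4,5-trimethoxyphenyl gives a number 7 percentage points higher from compound 2 to compound 4 (within the scatter) in this assay on this double-bonded chain carbon bound to a double-bonded chain carbon, so the place accepts the change without a step beyond the scatter. On this single pair, one aromatic ring and three hydrogen-bond acceptors stand where naphthalen-1-yl's two aromatic rings stood, and the reading holds. Nothing available explains this outcome. On these data alone, whether a dimethylamino group or a carboxylic acid would be accepted in this place remains open. So does whether the exchange holds on the chain of compound 1.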